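The source may hold more compounds than are shown below. What is called first, only, known or untested is meant among the compounds shown, and "the series" means these compounds.

Compound 1 `CC(C)(C)[C@@H](O)C(=O)N1CCS[C@H]1C(=O)NCc1cc(Cl)ccc1-n1cnnn1` gives 5.2 10^-6 cm/s
Compound 2 `O=C(NCc1cc(Cl)ccc1-n1cnnn1)[C@@H]1[C@@H]2C[C@@H]2CN1C(=O)[C@H](O)Cc1ccccn1` gives 0.62 10^-6 cm/s

In an ADME assay on Caco-2 cells (Homo sapiens) for permeability, read by LC-MS, in the apical to basolateral direction, with a stated time of 60 min, at pH 6.5 (a lower number here means that the compound crosses the layer more slowly, a higher number that the compound crosses the layer faster), compound 2 gives 0.62 10^-6 cm/s as the lower of the two numbers, and compound 1 at 5.2 10^-6 cm/s stands beyond the scatter from it. Compound 3 `O=C(NCc1cc(Cl)ccc1-n1cnnn1)[C@@H]1[C@@H]2C[C@@H]2CN1C(=O)[C@H](O)c1ccccc1` carries phenyl in place of (pyridin-2-yl)methyl on a saturated chain carbon bound to a carbonyl carbon and an oxygen on a saturated carbon. Going by the values given here, no measured pair shows this change, so any forecast is rough. The estimated step is a 2.9-fold higher number from compound 2 to compound 3 (0.46 log units; beyond the scatter) and it is expected to be a rise beyond the scatter in this assay for this pair. Compound 3 is expected at 1.8 10^-6 cm/s with 0.7 10^-6 cm/s to 5 10^-6 cm/s as the estimated range.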

Compound 3, apparent permeability: 2.2 10^-6 cm/s
The estimate for compound 3 lay 1.2-fold (0.09 log units) below the measured number; the range from low to high includes it.
By their numbers in this assay, from the lowest: compound 2; then compound 3; then compound 1.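

Going by these compounds alone, compound 2 and compound 3 are the first pair here that differ in one place, and in this assay phenyl in place of (pyridin-2-yl)methyl gives a 3.5-fold higher number from compound 2 to compound 3 (0.55 log units; beyond the scatter) and so shows that this position can shift the number beyond the scatter. The change removes the ring nitrogen and one heavy atom together, so this single step cannot separate the two. No measurement here explains the step. Benzyl or pyridin-2-yl at the same place would help separate them. Going by these compounds, what an amine there would do also remains open.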